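A Thiophene Swap at the Lowest-Inhibition Position

The source may hold more compounds than are shown below. What is called first, only, known or untested is meant among the compounds shown, and "the series" means these compounds.

Compound 2 `c1ccc2c(-c3cn4ccnc4c(-c4ccc5ncn(C6CCCCC6)c5c4)n3)cccc2c1` stands lowest of the three measured compounds in a functional assay on SK-MEL-5 cells (Homo sapiens) for inhibition, read by sulforhodamine B assay, with a stated time of 48 h, tested at 10 uM (a lower number here means less inhibition, a higher number more inhibition at the concentration tested (going by the name of the read-out)), giving 4.06%. Compound 1 `O=Cc1ccc(-c2cn3ccnc3c(-c3ccc4ncn(C5CCCCC5)c4c3)n2)cc1` gives 56.5% and compound 3 `c1cn2cc(-c3ccsc3)nc(-c3ccc4ncn(C5CCCCC5)c4c3)c2n1` gives 25%, so the aryl group at this position spans a wide range of inhibition. Compound 4 `c1csc(-c2cn3ccnc3c(-c3ccc4ncn(C5CCCCC5)c4c3)n2)c1` is the untested analogue; (thiophen-2-yl in place of naphthalen-1-yl on an aromatic carbon). The step that bears most directly on it is a number 20.9 percentage points higher from compound 2 to compound 3 (beyond the scatter), where the other thiophene isomer entered at the same position. The steps of a number 52.4 percentage points lower from compound 1 to compound 2 (beyond the scatter) and a number 31.5 percentage points lower from compound 1 to compound 3 (beyond the scatter) show that both replacements sit well below compound 1. Compound 4 is therefore expected to move modestly upward, a number 20.9 percentage points higher from compound 2 to compound 4 (beyond the scatter). Compound 4 is estimated to give 25%, within a range of 5% to 45%.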

Compound 4, a percentage reported as inhibition, at one concentration (the size of the read-out at that concentration, not a potency): 8.05%
For compound 4 the middle estimate is 17 percentage points above the measured one, within the range that was stated.
By their numbers in this assay, from the lowest: compounds 2 and 4 (each within the scatter of the next); then compound 3; then compound 1.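

In this assay the two thiophene isomers are not interchangeable at this position: there is a number 17 percentage points lower from compound 3 to compound 4 (beyond the scatter) when the point of attachment moves from thiophen-3-yl to thiophen-2-yl. The smaller thiophen-2-yl also brings no clear gain over naphthalen-1-yl, with a number 4 percentage points higher from compound 2 to compound 4 (within the scatter) for that swap, and 4-formylphenyl stays well ahead, with a number 48.5 percentage points lower from compound 1 to compound 4 (beyond the scatter) on its replacement. No measured evidence accounts for these differences. Still open is whether the formyl group itself matters, since no phenyl bearing a carboxylic acid, an amine or a nitrile at that place appears among these compounds.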